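This account rests on a few compounds, and the source may have more. Where it says the series, first, only, none or still open, it means among the compounds named here.

In a functional assay on EL4 cells (Mus musculus) for inhibition, tested at 100 uM (on this read-out higher numbers stand for more inhibition at the one concentration tested (going by the name of the read-out) and lower numbers for less inhibition), two compounds have been measured so far. Compound 1 `[N-]=[N+]=Nc1nccc2c1ncn2[C@H]1C[C@H](O)[C@@H](CO)O1` gives 13% in this assay, and compound 2 `CCNc1nccc2c1ncn2C1O[C@H](CO)[C@@H](O)[C@H]1O` gives 8%. Compound 1 carries the higher of the two numbers, but the gap to compound 2 lies within the scatter of repeated measurements, so the two cannot be told apart on this read-out.

Compound 3 `CN(C)c1nccc2c1ncn2[C@H]1C[C@H](O)[C@@H](CO)O1` has not yet been measured. It differs from compound 1 in a single place: dimethylamino in place of azido on an aromatic carbon. Going by the values given here, no pair of measured compounds shows how a change at this place moves the read-out, and both numbers in hand sit in the low range of this assay. The expected step is therefore small, none beyond the scatter: a number 3 percentage points lower from compound 1 to compound 3 (within the scatter). Compound 3 is estimated to give about 10% in this assay, within a range from 0% to 25%.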

Compound 3, a percentage reported as inhibition, at one concentration (the size of the read-out at that concentration, not a potency): < 5%
Compound 3 was reported as a limit (the forecaster's own chance of this, stated with the estimate: 0%); middle value at least 5 percentage points away from the limit.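

In this assay compound 3 is reported only as a limit, < 5%, not as a number. Going by these compounds alone, this gives a first reading of a change on this aromatic carbon next to the ring nitrogen: putting dimethylamino in place of azido gives a number at least 8 percentage points lower from compound 1 to compound 3 (that floor lies within the scatter). So the change does not clearly move the read-out, and its true size cannot be read because one end of the step is a limit: the limit of < 5% in this assay, at which 1 of the 3 values shown sits.

The compounds shown do not tell whether a plain amine, a methoxy group or a longer chain on this carbon would give a number clearly apart from that of compound 1. With a single step at this place, they also leave open whether any group here can raise the read-out beyond the scatter.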